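This account rests on a few compounds, and the source may have more. Where it says the series, first, only, none or still open, it means among the compounds named here.

Compound 1 `CC(=O)Oc1cccc2cc(-c3cccs3)c(=O)oc12` is the starting point. In an assay on CHO cells for displacement of a labelled ligand from adenosine receptor A1 (Homo sapiens) (a higher number here means a weaker inhibitor, a lower number a stronger inhibitor), compound 1 gives > 100000 nM, which is a limit of the measurement rather than a number. Two related compounds have also been tested. Compound 2 `CC(=O)Oc1ccc2cc(-c3cccs3)c(=O)oc2c1OC(C)=O` gives > 100000 nM in this assay, again only a limit. Compound 3 `CC(=O)Oc1cccc2cc(-c3cc(Br)cs3)c(=O)oc12` gives > 100000 nM in this assay, also a limit. The steps a step that the two limits leave unreadable from compound 1 to compound 2 and a step that the two limits leave unreadable from compound 1 to compound 3 cannot be sized, because of the limit of > 100000 nM in this assay, at which 3 of the 3 values shown sit. Neither step touches the acetyl group, so neither bears directly on the change considered here.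

Compound 4 `O=c1oc2c(O)cccc2cc1-c1cccs1` differs from compound 1 by hydrogen in place of acetyl on an oxygen on an aromatic ring. With every measured value resting at the limit, the data give no footing for expecting a gain, and the free hydroxy compound is expected to stay in the same weak region. The step from compound 1 to compound 4 is therefore estimated as a number no higher from compound 1 to compound 4 (the limit leaves the size open), with a strong chance that again only a limit is recorded. Compound 4 is thus estimated at 100000 nM, within a range from 10000 nM to 300000 nM.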

Compound 4, inhibition constant: 3360 nM
Compound 4: middle estimate off by 30-fold (1.47 log units), on the high side, outside the stated range (below it).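

Replacing acetyl with hydrogen on the oxygen on the aromatic ring, which turns acetoxy into hydroxy, gives an at least 29-fold lower number from compound 1 to compound 4 (1.47 log units; beyond the scatter) in this assay. Within the data shown here, compound 4 is the first compound here with a real number, which shows that this oxygen is a place where a change can be read, something the unreadable steps to compound 2 and compound 3 could not show: the limit of > 100000 nM in this assay, at which 3 of the 4 values shown sit. The value of compound 1, > 100000 nM, is a limit, so the full size of the step stays open.

Going by these compounds, it remains open whether the free hydroxy itself matters or only the loss of acetyl, and a methyl ether or a longer ether chain on this oxygen, or an amine in place of the hydroxy, would help separate the two. Also open, on these data alone, is how a bromo on the thiophene would act alongside the free hydroxy.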